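The source may hold more compounds than are shown below. What is called first, only, known or untested is meant among the compounds shown, and "the series" means these compounds.

Measured compounds in a functional assay on SW1573 cells (Homo sapiens) for antiproliferative activity; on this read-out lower numbers stand for stronger inhibition of growth and higher numbers for weaker inhibition of growth:

compound 1 `C[C@H]1CC(Cl)=C([Si](C)(C)C)[C@@H](C2CCCCC2)O1`: 16000 nM
compound 2 `C[Si](C)(C)C1=C(Cl)C[C@H](C2CCCCC2)O[C@@H]1C1CCCCC1`: 23000 nM
compound 3 `C[Si](C)(C)C1=C(Cl)C[C@H](Cc2ccccc2)O[C@@H]1C1CCCCC1`: 30000 nM

Compound 1 holds the lowest number of the set in this assay, but its distances to the others are small: a 1.4-fold higher number from compound 1 to compound 2 (0.16 log units; within the scatter) and a 1.9-fold higher number from compound 1 to compound 3 (0.27 log units; within the scatter), both within the scatter. The step between the other pair, a 1.3-fold higher number from compound 2 to compound 3 (0.12 log units; within the scatter), is also within the scatter. All changes measured so far sit on the ring carbon away from the silyl-bearing side or on its chain, and none of them moves the read-out beyond the usual spread.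

Compound 4 `C[C@@H]1O[C@H](C2CCCCC2)C([Si](C)(C)C)=C(Cl)[C@H]1C` differs from compound 1 by methyl in place of hydrogen on a saturated ring carbon. For the measured compounds named here, no measured step alters this position, so no direct precedent exists; the only guidance is that every substitution on the shared core examined so far, including the larger cyclohexyl and benzyl exchanges, left this assay essentially unchanged. A small added methyl is therefore expected to do the same, with no step beyond the scatter in either direction. Compound 4 is estimated at 17000 nM (range 7000 nM to 40000 nM), which means an expected step of a 1.1-fold higher number from compound 1 to compound 4 (0.03 log units; within the scatter).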

Compound 4, concentration for 50% growth inhibition: 20000 nM
For compound 4 the middle estimate is 1.2-fold (0.07 log units) below the measured one; measured number inside the range.
By their numbers in this assay, from the lowest: compounds 1, 4, 2 and 3 (each within the scatter of the next).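

In this assay, for the compounds shown here, methyl in place of hydrogen on the saturated ring carbon next to the ring atom that bears a chloro group gives a 1.3-fold higher number from compound 1 to compound 4 (0.10 log units; within the scatter), a change at a position that no earlier step altered. This carbon therefore accepts a methyl group with no step beyond the scatter, and the flat picture seen with the cyclohexyl and benzyl exchanges now extends to a second place on the shared core. No supporting measurement is available to explain this result.

On these data alone, whether this carbon tolerates more than a methyl group stays open, since a longer chain, an amine or a carboxylic acid there could still give a step beyond the scatter. The compounds shown also leave open which change to the shared core, if any, would move this read-out beyond the scatter.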